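The source may hold more compounds than are shown below. What is called first, only, known or untested is meant among the compounds shown, and "the series" means these compounds.

Measured compounds:
Compound 1 `O=C(Cc1nn(CC(=O)N2CCOCC2)c(=O)c2ccccc12)Nc1ccc(OC(F)(F)F)c(Cl)c1` — in a functional assay on CHO cells for antagonist activity at sphingosine 1-phosphate receptor 2 (Homo sapiens), read by GTPgammaS binding (on this read-out higher numbers stand for weaker inhibition and lower numbers for stronger inhibition), compound 1 gives 103 nM.
Compound 2 `O=C(O)Cn1nc(CC(=O)Nc2ccc(OC(F)(F)F)c(Cl)c2)c2ccccc2c1=O` — compound 2 gives 754 nM.

For the measured compounds named here, compound 2 stands highest of the two numbers; the only measured step, a 7.3-fold higher number from compound 1 to compound 2 (0.86 log units; beyond the scatter), replaces morpholin-4-yl with hydroxy on a carbonyl carbon. Compound 3 `O=C(Cc1nn(C2CC2)c(=O)c2ccccc12)Nc1ccc(OC(F)(F)F)c(Cl)c1` differs from compound 2 by cyclopropyl in place of carboxymethyl on an aromatic nitrogen. Going by the values given here, no measured step touches this position, so the expectation rests on the neutral amide compound 1 giving 103 nM. Compound 3 is expected near 120 nM, within 30 nM to 500 nM. This expectation amounts to a 6.3-fold lower number from compound 2 to compound 3 (0.80 log units; beyond the scatter).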

Compound 3, half-maximal inhibitory concentration in the sphingosine 1-phosphate receptor 2 assay: 565 nM
Estimate against measurement, compound 3: 4.7-fold (0.67 log units) below, and the stated range ends below it.
By their numbers in the sphingosine 1-phosphate receptor 2 assay, from the lowest: compound 1; then compounds 3 and 2 (each within the scatter of the next).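

In the sphingosine 1-phosphate receptor 2 assay, cyclopropyl and carboxymethyl at this ring nitrogen cannot be told apart (a 1.3-fold lower number from compound 2 to compound 3 (0.13 log units; within the scatter)). The ((morpholin-4-yl)carbonyl)methyl group of compound 1 still gives the lower number (a 5.5-fold higher number from compound 1 to compound 3 (0.74 log units; beyond the scatter)), so removing the carboxylic acid does not by itself match compound 1. In a physicochemical assay for lipophilicity, at pH 7.4 (a lower number here means a more polar compound, a higher number a more lipophilic compound), compound 2 gives 2.92 and compound 3 gives 5.43. Inhibition therefore does not follow lipophilicity across this pair in the physicochemical assay: the measured distribution coefficient of compound 2, 2.92, and of compound 3, 5.43, a number 2.51 log units higher (beyond the scatter).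

As far as these compounds go, what remains open is which part of the morpholine amide side chain matters. A piperidine amide or a dimethylamide on the same chain could help separate the role of the ring oxygen from that of the amide.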